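A few compounds are considered here, and "the series" means these few. Any claim that something is new, unique, unknown or untested is made for them only; others in the source may bear on it.

Compound 2 `COc1ccc(-c2cc3ccccc3nc2/C=C/C(=O)c2ccco2)cc1` carries a 2-((furan-2-yl)carbonyl)ethenyl group on its shared core. Going by the values given here, in a functional assay on MDA-MB-231 cells (Homo sapiens) for antiproliferative activity, read by XTT assay, with a stated time of 72 h (a higher number here means a weaker inhibitor, a lower number a stronger inhibitor), compound 2 gives 630 nM, the only true number among the values shown. Compound 1 `COc1ccc(-c2cc3ccccc3nc2C=O)cc1` carries a formyl group at that same place, and in this assay compound 1 gives > 10000 nM, which is a limit of the assay rather than a number. The step of an at least 15-fold lower number from compound 1 to compound 2 (1.20 log units; beyond the scatter) turns that limit into a measurable value. Compound 3 `COc1ccc(-c2cc3ccccc3nc2/C=C/C(=O)c2c[nH]c3ccccc23)cc1` differs from compound 2 in one place: 1H-indol-3-yl in place of furan-2-yl on a carbonyl carbon. Among the compounds with values here, no measured step alters the group on the carbonyl carbon, so the single measured step, an at least 15-fold lower number from compound 1 to compound 2 (1.20 log units; beyond the scatter), concerns a different change and offers no direct guide. The expected step is a 1.3-fold lower number from compound 2 to compound 3 (0.10 log units; within the scatter), within the scatter. The estimate for compound 3 in this assay is 500 nM, with a range from 150 nM to 2000 nM.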

Compound 3, half-maximal inhibitory concentration: > 10000 nM
Compound 3: only a limit was reported; the forecaster's own chance of this, stated with the estimate: 5%; at least 20-fold (1.30 log units) between middle value and limit.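

Exchanging furan-2-yl for 1H-indol-3-yl on the carbonyl carbon is far from a neutral change in this assay: it gives an at least 15-fold higher number from compound 2 to compound 3 (1.20 log units; beyond the scatter). Going by these compounds alone, compound 1 showed only that replacing the formyl group could bring a measurable value; compound 3 keeps the carbonyl-bearing chain of compound 2 yet loses that value, so the chain alone does not ensure activity and the group on this carbonyl carbon also counts. The reading for compound 3 is a limit of the assay rather than a number, so the true size of this step remains unknown: the limit of > 10000 nM in this assay, at which 2 of the 3 values shown sit.

The 1H-indol-3-yl group differs from furan-2-yl by both an added six-membered aromatic ring and a hydrogen-bond donor, and these two differences cannot be separated here. As far as these compounds go, how a phenyl or a pyrrol-2-yl group would behave on this carbonyl carbon remains open.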